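The source may report more compounds than this note shows. Statements on the series, on what has been measured and on what is new or still open speak of the compounds shown alone.

The series shares one core, carried by compound 1 (`COc1ccc(/C=C\c2cc(OC)c(OC)c(OC)c2)cc1OCc1ccc(CN2CCCC[C@@H]2C(=O)O)cc1`), compound 2 (`COc1ccc(/C=C\c2cc(OC)c(OC)c(OC)c2)cc1OCc1ccc(CN[C@H](C(=O)O)[C@H](C)O)cc1`) and compound 3 (`COc1ccc(/C=C\c2cc(OC)c(OC)c(OC)c2)cc1OCc1ccc(CN2CCCCC2C(=O)NCCNC(=O)OC(C)(C)C)cc1`). In a functional assay on B16-F10 cells (Mus musculus) for antiproliferative activity, read by CCK-8 assay, with a stated time of 48 h (a higher number here means a weaker inhibitor, a lower number a stronger inhibitor), compound 2 gives > 10000 nM, which is a limit and not a number. Compound 1 gives > 10000 nM, which is also a limit. Compound 2 therefore stands at the limit of > 10000 nM in this assay, at which 2 of the 3 values shown sit. Going by the values given here, the only measured step, a step that the two limits leave unreadable from compound 1 to compound 2, offers no size to carry forward. Where compound 1 has a free carboxy group, compound 3 has an amide, and compound 3 gives a true number of 4700 nM.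

Compound 4 (`COc1ccc(/C=C\c2cc(OC)c(OC)c(OC)c2)cc1OCc1ccc(CNCCN(C)C)cc1`) changes the side chain of compound 2: 2-(dimethylamino)ethyl in place of 1-carboxy-2-hydroxypropyl on an amine nitrogen. Among the compounds with values here, its 2-(dimethylamino)ethyl on an amine nitrogen leaves it without a free carboxy group, as in compound 3, so a measurable value is expected, with compound 3 at 4700 nM as the only guide. The expected change in this assay is an at least 3.3-fold lower number from compound 2 to compound 4 (0.52 log units; beyond the scatter), towards a stronger inhibitor, though its size is uncertain. Compound 4 is estimated at 3000 nM, with an expected range from 500 nM to 10000 nM.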

Compound 4, half-maximal inhibitory concentration: > 10000 nM
Compound 4: only a limit was reported (the forecaster's own chance of this, stated with the estimate: 20%); middle value at least 3.3-fold (0.52 log units) from the limit.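

In this assay compound 4 gives > 10000 nM, which is a limit and not a number. Its steps from compound 1 and compound 2 therefore cannot be read, and compound 2 stays where it stood: the limit of > 10000 nM in this assay, at which 3 of the 4 values shown sit. Left open is what separates compound 3, the only compound with a true number, from the other three.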